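The source may hold more compounds than are shown below. What is called first, only, known or untested is meant among the compounds shown, and "the series" means these compounds.

In a functional assay on BJAB cells (Homo sapiens) for antiproliferative activity, with a stated time of 4 days (a lower number here means that less compound is needed, a higher number that more compound is needed for the effect), three compounds have been measured. Compound 1 `CCSc1sc(-n2nc(C)c(Cc3ccccc3[N+](=O)[O-])c2C(=O)O)nc1-c1ccc(Cl)c(Cl)c1` gives 59000 nM, compound 3 `Cc1c(-c2cc(Cl)cc(Cl)c2)c(C(=O)O)nn1-c1nc(-c2cc(Cl)ccc2F)c(SC(C)C)s1` gives 4800 nM, and compound 2 `Cc1cc(-c2c(C)nn(-c3nc(-c4ccc(Cl)c(Cl)c4)c(SC(C)C)s3)c2C(=O)O)cc(C)n1` gives 580 nM, the lowest of the three; its gaps to compound 3 and to compound 1 both lie beyond the usual scatter, so compound 2 is the most potent compound seen so far. The next compound, compound 4 `CNc1cc(-c2c(C)nn(-c3nc(-c4ccc(Cl)c(Cl)c4)c(SC(C)C)s3)c2C(=O)O)ccn1`, keeps the shared core of compound 2 and differs from it in one place: 2-(methylamino)pyridin-4-yl in place of 2,6-dimethylpyridin-4-yl on an aromatic carbon. Among the measured compounds shown here, no pair of measured compounds differs in exactly this way, so there is no measured step to lean on; the reading rests on compound 2 alone, with its value of 580 nM. A moderate rise in this assay is expected, of a size somewhat beyond the scatter, though a result within the scatter of compound 2 would not surprise. Compound 4 is therefore estimated at 1500 nM, with a range from 400 nM to 6000 nM, which means an expected step of a 2.6-fold higher number from compound 2 to compound 4 (0.41 log units; beyond the scatter).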

Compound 4, half-maximal effective concentration: 18000 nM
For compound 4 the middle estimate is 12-fold (1.08 log units) below the measured one; the whole stated range lies below it.
By their numbers in this assay, from the lowest: compound 2; then compound 3; then compound 4; then compound 1.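

Replacing 2,6-dimethylpyridin-4-yl with 2-(methylamino)pyridin-4-yl on this aromatic carbon is a large change in this assay (a 31-fold higher number from compound 2 to compound 4 (1.49 log units; beyond the scatter)), even though both groups have 8 heavy atoms and one six-membered aromatic ring with 1 hetero atom. This one-place comparison shows that the position responds strongly to the substitution on that ring, with the entering group bringing 1 hydrogen-bond donor where the leaving group has none. Nothing given here explains the rise. The compounds shown do not separate the effect of the amine hydrogen from that of losing the methyl groups. A 2-(dimethylamino)pyridin-4-yl group, which has no such hydrogen, would bear directly on that question, and a 2-methylpyridin-4-yl group would show what a single methyl group contributes.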